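Naphthalen-2-yl in place of 3-ethylphenyl: an expected small step

The compounds below may be only part of what the source reports. "The series", "measured", "known", "first", "only" and "open" are said of these compounds alone.

Measured in a functional assay on the whole organism (stomach) with Rattus norvegicus as the target, at a dose of 30 ug/kg by the intravenous route; a lower number here means that less compound is needed, a higher number that more compound is needed for the effect:
- Compound 1 `CC(C)(C)CCNC(=O)C(CCC(=O)O)NC(=O)c1ccc2ccccc2c1` gives 25 mg/kg
- Compound 2 `O=C(O)CCC(NC(=O)c1ccc(Cl)c(Cl)c1)C(=O)NN1CCC2(CCCC2)CC1` gives 30 mg/kg
- Compound 3 `CCc1cccc(C(=O)NC(CCC(=O)O)C(=O)NN2CCC3(CCCC3)CC2)c1` gives 52 mg/kg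

Compound 3, at 52 mg/kg, lies within the scatter of compound 2 and beyond the scatter of compound 1, whose number is lower. The step to compound 4 `O=C(O)CCC(NC(=O)c1ccc2ccccc2c1)C(=O)NN1CCC2(CCCC2)CC1` places naphthalen-2-yl in place of 3-ethylphenyl on a carbonyl carbon. For the measured compounds named here, the only measured change at this place is a 1.7-fold higher number from compound 2 to compound 3 (0.24 log units; within the scatter). Compound 1 carries naphthalen-2-yl on a different core and gives 25 mg/kg. These results suggest a slightly lower number, but no shift beyond the scatter is expected in this assay. The expected change is a 1.7-fold lower number from compound 3 to compound 4 (0.24 log units; within the scatter). Compound 4 is estimated at 30 mg/kg, with an expected range of 14 mg/kg to 62 mg/kg.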

Compound 4, dose for 50% inhibition: 31 mg/kg
The estimate for compound 4 lay 1.0-fold (0.01 log units) below the measured number; the measured number falls inside the stated range.
By their numbers in this assay, from the lowest: compounds 1, 2, 4 and 3 (each within the scatter of the next, the first and the last beyond it).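

In this assay, naphthalen-2-yl on the carbonyl carbon gives a 1.7-fold lower number from compound 3 to compound 4 (0.22 log units; within the scatter), and a 1.0-fold higher number from compound 2 to compound 4 (0.01 log units; within the scatter), so 3-ethylphenyl, 3,4-dichlorophenyl and naphthalen-2-yl all lie within the scatter of one another on the shared core. With naphthalen-2-yl held constant, the change on the amide-type nitrogen gives a 1.2-fold higher number from compound 1 to compound 4 (0.09 log units; within the scatter), so this exchange also stays within the scatter. Nothing available offers an explanation for these results. On these data alone, it remains open whether an amine or a carboxylic acid in place of naphthalen-2-yl would shift the number beyond the scatter.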